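The source may report more compounds than this note shows. Statements on the series, on what has been measured and on what is new or still open speak of the compounds shown alone.

Compound 1 `Nc1cc(N)c2nc(-c3ccccc3)c(NCc3ccc(Cl)c(Cl)c3)nc2c1` gives 69200 nM in a functional assay on DU-145 cells (Homo sapiens) for inhibition, read by sulforhodamine B assay, with a stated time of 48 h; a higher number here means that more compound is tolerated, a lower number that less compound is tolerated. Compound 2 `COc1ccc(CNc2nc3cc(N)cc(N)c3nc2-c2ccccc2)cc1OC` reaches only a limit in this assay, namely < 100000 nM. The step that the limit leaves unreadable from compound 1 to compound 2 therefore has no readable size because the limit of < 100000 nM in this assay, at which 1 of the 2 values shown sits, caps one of its two values. Compound 3 `COc1cc(CNc2nc3cc(N)cc(N)c3nc2-c2ccccc2)cc(OC)c1OC` differs from compound 2 by methoxy in place of hydrogen on an aromatic carbon. Going by the values given here, no measured step with a readable size bears on this change, so no direction beyond the scatter can be expected. Compound 3 is estimated to give about 60000 nM, with a range from 20000 nM to 200000 nM. The step that the limit leaves unreadable from compound 2 to compound 3 is likewise only an expectation.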

Compound 3, concentration lethal to 50% of the cells: < 50200 nM
Compound 3: a limit, no number; the forecaster's own chance of this, stated with the estimate: 50%; at least 1.1-fold (0.07 log units) between middle value and limit.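

Going by these compounds alone, compound 2 and compound 3 both give only limits, not numbers, in this assay, so no step between them can be read. As far as these compounds go, whether the added methoxy changes the lethal concentration, and in which direction, remains open.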